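Nitro Removal in Two Benzyloxy Aniline Series

A few compounds are considered here, and "the series" means these few. Any claim that something is new, unique, unknown or untested is made for them only; others in the source may bear on it.

The study compares four compounds built on the same core, differing in a benzyloxy substituent and in where the aniline is joined. Compound 1 `O=[N+]([O-])c1ccc(COc2ccc(Nc3ncnc4cc5c(cc34)OCCOCCO5)cc2)cc1` carries a nitro group on the benzyl ring; in a functional assay on A549 cells (Homo sapiens) for antiproliferative activity, read by MTT assay, with a stated time of 72 h (on this read-out higher numbers stand for weaker inhibition and lower numbers for stronger inhibition), compound 1 gives 8620 nM. Compound 2 `c1ccc(COc2ccc(Nc3ncnc4cc5c(cc34)OCCOCCO5)cc2)cc1` lacks that nitro group, and in this assay compound 2 gives 43900 nM. The change between them, (hydrogen in place of nitro on an aromatic carbon), produced a 5.1-fold higher number from compound 1 to compound 2 (0.71 log units; beyond the scatter).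

Compound 3 `O=[N+]([O-])c1ccc(COc2cccc(Nc3ncnc4cc5c(cc34)OCCOCCO5)c2)cc1` keeps the nitro group but joins the aniline to the core at a different position; how the core of compound 3 differs from the core of compound 1 is not broken down here. In this assay compound 3 gives 15500 nM, a number close to that of compound 1 and lying within the usual scatter of it, while compound 2 stands well above both.

Compound 4 `c1ccc(COc2cccc(Nc3ncnc4cc5c(cc34)OCCOCCO5)c2)cc1` is not yet measured. It relates to compound 3 by hydrogen in place of nitro on an aromatic carbon, the same change that turned compound 1 into compound 2, at the same kind of place. Because a 5.1-fold higher number from compound 1 to compound 2 (0.71 log units; beyond the scatter) was a clear loss of potency, compound 4 is expected to show a step of similar size, estimated as a 4.5-fold higher number from compound 3 to compound 4 (0.65 log units; beyond the scatter). On that basis compound 4 is expected to give about 70000 nM in this assay, with a likely range from 30000 nM to 160000 nM.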

Compound 4, half-maximal inhibitory concentration: 7590 nM
The estimate for compound 4 lay 9.2-fold (0.96 log units) above the measured number, outside the stated range (below it).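

In this assay, the change from (4-nitrobenzyl)oxy to benzyloxy gave a 2.0-fold lower number from compound 3 to compound 4 (0.31 log units; beyond the scatter) and thus ran opposite to a 5.1-fold higher number from compound 1 to compound 2 (0.71 log units; beyond the scatter) on the core of compound 1. The same replacement of nitro by hydrogen therefore did not carry from one core to the other, and the two steps differ in direction and by more than the scatter allows: the same change on two cores in this assay, a 5.1-fold higher number (0.71 log units; beyond the scatter) from compound 1 to compound 2 and a 2.0-fold lower number (0.31 log units; beyond the scatter) from compound 3 to compound 4, 10-fold (1.02 log units) apart, beyond the scatter of two such steps. Among the compounds shown here, this shows that, in these two pairs, the outcome of removing the nitro group depended on the core that carried it, but with only two pairs it does not show what in the difference between the cores lies behind the reversal, nor how the same change would behave on any further core.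

The compounds shown leave open whether this reversal belongs to nitro alone, since no other group, such as an amine, a nitrile or a carboxylic acid, appears on the benzyl ring para to a large group on either core. They also leave open whether a longer chain between the benzyl ring and the aniline oxygen would keep the two cores apart in the same way.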